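Replacing a chloropropyl urea with an acrylamide on a shared core

This account rests on a few compounds, and the source may have more. Where it says the series, first, only, none or still open, it means among the compounds named here.

Two compounds sharing a tert-butylphenyl core were tested in a functional assay on M21 cells (Homo sapiens) for antiproliferative activity, with a stated time of 48 h; on this read-out higher numbers stand for weaker inhibition and lower numbers for stronger inhibition. Compound 1 `CC(C)(C)c1ccc(CNC(=O)NCCCCl)cc1` carries a (3-chloropropyl)urea on the benzylic amine, and in this assay compound 1 gives 11000 nM. Compound 2 `CC(C)(C)c1ccc(NC(=O)CCCl)cc1` instead bears a 3-chloropropanamide directly on the aromatic amine, and in this assay compound 2 gives 74000 nM. Compound 1 therefore holds the lower of the two numbers, and the gap to compound 2 lies beyond the usual scatter of repeated measurements.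

Compound 3 `C=CC(=O)NCc1ccc(C(C)(C)C)cc1` is derived from compound 1 by a single change: vinyl in place of (3-chloropropyl)amino on a carbonyl carbon. Going by the values given here, no measured pair exhibiting this particular exchange is available, so the expected direction rests on the structures alone. The step from compound 1 to compound 3 is estimated as a modest shift toward a lower number, a 1.6-fold lower number from compound 1 to compound 3 (0.20 log units; within the scatter). On that basis compound 3 is expected to give about 7000 nM in this assay, within a range of 2000 nM to 25000 nM.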

Compound 3, half-maximal inhibitory concentration: 72000 nM
Estimate against measurement, compound 3: 10-fold (1.01 log units) below; the measured number lies above the stated range.
By their numbers in this assay, from the lowest: compound 1; then compounds 3 and 2 (each within the scatter of the next).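

In this assay, vinyl in place of (3-chloropropyl)amino on a carbonyl carbon gives a 6.5-fold higher number from compound 1 to compound 3 (0.82 log units; beyond the scatter) and so lies beyond the scatter. This is the first exchange shown at this position, as compound 1 and compound 2 differ in more than one place and could not isolate its effect. It shows that the number responds to the group on this carbonyl carbon, and that vinyl does not preserve the inhibition seen with (3-chloropropyl)amino on the shared core. Nothing available here bears on why the number moves in this direction.

On these data alone, it remains open whether the chlorine atom matters or the chain and its nitrogen are enough. A plain propylamino group, or a 3-hydroxypropylamino group, on the same carbonyl carbon would separate these possibilities.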